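Triazole nitrogen substituent and tolerance on HepG2 cells

The compounds below may be only part of what the source reports. "The series", "measured", "known", "first", "only" and "open" are said of these compounds alone.

Compound 1 `CC(C)=CCC1=C(OCc2cn(Cc3ccccn3)nn2)C(=O)c2ccccc2C1=O` in an ADME assay on HepG2 cells (Homo sapiens) for cytotoxicity, read by MTT assay, with a stated time of 24 h (a lower number here means that less compound is tolerated, a higher number that more compound is tolerated), gives 658000 nM, the lowest of the two numbers in hand. Among the compounds with values here, its only neighbour is compound 2 `CC(C)=CCC1=C(OCc2cn(-c3ccc(C#N)cc3)nn2)C(=O)c2ccccc2C1=O`, which in this assay gives 707000 nM, and the two stand within the scatter of each other.

Compound 3 `COc1ccc(-n2cc(COC3=C(CC=C(C)C)C(=O)c4ccccc4C3=O)nn2)cc1` differs from compound 1 in one place: 4-methoxyphenyl in place of (pyridin-2-yl)methyl on an aromatic nitrogen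

Within the data shown here, the one measured step that bears on this change is a 1.1-fold higher number from compound 1 to compound 2 (0.03 log units; within the scatter), where a six-membered aromatic ring of carbon only also replaced the (pyridin-2-yl)methyl group on an aromatic nitrogen, and the number hardly moved. Nothing in hand points to a different outcome for 4-methoxyphenyl, so no step beyond the scatter in this assay is expected in either direction. Compound 3 is therefore estimated at 680000 nM, with a range from 340000 nM to 1360000 nM. The expected step of a 1.0-fold higher number from compound 1 to compound 3 (0.01 log units; within the scatter) is thus within the scatter.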

Compound 3, half-maximal cytotoxic concentration: 200000 nM
Beside the measured number, compound 3's estimate is 3.4-fold (0.53 log units) above it; measured number outside the range, below it.
By their numbers in this assay, from the lowest: compound 3; then compounds 1 and 2 (each within the scatter of the next).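

Tolerance on HepG2 cells does respond to the group on this aromatic nitrogen: in this assay the step is a 3.3-fold lower number from compound 1 to compound 3 (0.52 log units; beyond the scatter), so the flat result seen with 4-cyanophenyl does not extend to every six-membered aromatic ring of carbon only. With that ring kept, methoxy in place of cyano on an aromatic carbon gives a 3.5-fold lower number from compound 2 to compound 3 (0.55 log units; beyond the scatter), which places the change on the ring substituent rather than on the ring alone. No measurement in hand accounts for this lower number.

As far as these compounds go, whether it is particular to methoxy remains open, and an amine or a hydroxy group on that aromatic carbon would test this. A plain benzyl group on the aromatic nitrogen would show how far compound 1 depends on its ring nitrogen.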